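Neopentyl in Place of Methyl: Estimating Compound 4

The compounds below may be only part of what the source reports. "The series", "measured", "known", "first", "only" and "open" are said of these compounds alone.

Measured compounds in an assay on CHO cells for displacement of a labelled ligand from adenosine receptor A1 (Homo sapiens), read by scintillation counting, with a stated time of 3 h; on this read-out higher numbers stand for weaker inhibition and lower numbers for stronger inhibition:
Compound 1, `Cc1ccc(C(=O)Nc2nc(Cl)c3cn(CC(C)(C)C)nc3n2)cc1`, gives 11100 nM.
Compound 2, `CC(C)(C)Cn1cc2c(Cl)nc(NC(=O)c3ccccc3)nc2n1`, gives 11000 nM.
Compound 3, `Cn1cc2c(Cl)nc(NC(=O)c3ccc(C(F)(F)F)cc3)nc2n1`, returns only a limit, > 100000 nM, meaning the assay reports no number for it.

Compound 3 therefore stands at the edge of what this assay can measure, as the limit of > 100000 nM in this assay, at which 1 of the 3 values shown sits, shows; on the numbers shown it is the one compound without a value of its own. Compound 4, `CC(C)(C)Cn1cc2c(Cl)nc(NC(=O)c3ccc(C(F)(F)F)cc3)nc2n1`, differs from it in one place: tert-butyl in place of hydrogen on a saturated chain carbon bound to an aromatic nitrogen. Seen one bond further out, the same change reads methyl to neopentyl.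

Within the data shown here, no measured pair captures this particular change. Among the measured compounds shown here, the one measured step, a 1.0-fold lower number from compound 1 to compound 2 (0.00 log units; within the scatter), concerns a different place, the amide ring, and sits within the scatter. What the data do show is that compound 1 and compound 2, both carrying neopentyl at the aromatic nitrogen, land close together in this assay, whereas compound 3, carrying methyl, gives only a limit.

On that basis compound 4 is expected to behave like the neopentyl compounds rather than like compound 3, and the step of an at least 6.6-fold lower number from compound 3 to compound 4 (0.82 log units; beyond the scatter) is expected to be a move toward stronger inhibition. The estimate for compound 4 is 15000 nM, within a range from 4000 nM to 100000 nM.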

Compound 4, inhibition constant: > 100000 nM
Compound 4: only a limit was reported; the forecaster's own chance of this, stated with the estimate: 25%; at least 6.6-fold (0.82 log units) between middle value and limit.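

Compound 4 carries neopentyl on the aromatic nitrogen in this assay and still returns only a limit, not a number, so neopentyl alone does not secure a measurable value. Compound 3, with methyl at that nitrogen, also returns only a limit, and the two limits together sit at the edge of the assay: the limit of > 100000 nM in this assay, at which 2 of the 4 values shown sit. The size of the change from methyl to neopentyl therefore cannot be read, and the clear signal comes from the other place, where trifluoromethyl on an aromatic carbon gives an at least 9.0-fold higher number from compound 2 to compound 4 (0.95 log units; beyond the scatter) when it replaces hydrogen and an at least 9.0-fold higher number from compound 1 to compound 4 (0.95 log units; beyond the scatter) when it replaces methyl.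

Among the compounds shown, the only one with methyl at the nitrogen has no number of its own, so it remains open whether neopentyl and methyl differ at all in this assay. Also open, from the compounds shown here alone, is how a methoxy group on that aromatic carbon, or a longer chain such as hexyl on the aromatic nitrogen, would read.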